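Pyrimidinyl for difluorophenyl: from compound 2 to compound 3

The compounds below may be only part of what the source reports. "The series", "measured", "known", "first", "only" and "open" are said of these compounds alone.

Measured so far:
Compound 1, `CC[C@H](C)[C@H](N)CN(C(=O)[C@@H]1C[C@H]1c1cccc(C)c1)c1ccc(-c2ccccc2)cc1`: 1200 nM
Compound 2, `CC[C@H](C)[C@H](N)CN(C(=O)[C@@H]1C[C@H]1c1cc(F)cc(F)c1)c1ccc(-c2ccccc2)cc1`: 960 nM

Within the data shown here, in a functional assay for agonist activity at G protein-coupled receptor 88 (Homo sapiens), read by HTRF and cAMP accumulation (on this read-out higher numbers stand for an effect only at larger amounts of compound and lower numbers for an effect already at smaller amounts), compound 2 gives 960 nM and compound 1 gives 1200 nM; the single step of a 1.3-fold lower number from compound 1 to compound 2 (0.10 log units; within the scatter) lies within the scatter, so the two numbers are read as equal. Compound 3, `CC[C@H](C)[C@H](N)CN(C(=O)[C@@H]1C[C@H]1c1cncnc1)c1ccc(-c2ccccc2)cc1`, is unmeasured and differs from compound 2 by pyrimidin-5-yl in place of 3,5-difluorophenyl on a saturated ring carbon. Among the measured compounds shown here, the only measured step concerns another aryl exchange at the same saturated ring carbon and moved nothing, but no measured step covers a ring with hetero atoms, so the expectation is uncertain. Compound 3 is expected to give 1500 nM in this assay, within 500 nM to 4500 nM. The expected step is a 1.6-fold higher number from compound 2 to compound 3 (0.19 log units; within the scatter).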

Compound 3, half-maximal effective concentration: 19000 nM
For compound 3 the middle estimate is 13-fold (1.10 log units) below the measured one; measured number above the stated range.
By their numbers in this assay, from the lowest: compounds 2 and 1 (each within the scatter of the next); then compound 3.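

In this assay the saturated ring carbon proves sensitive to the ring it carries, which the exchange between 3-methylphenyl and 3,5-difluorophenyl did not reveal. Pyrimidin-5-yl gives a 20-fold higher number from compound 2 to compound 3 (1.30 log units; beyond the scatter) and also a 16-fold higher number from compound 1 to compound 3 (1.20 log units; beyond the scatter) in the same direction. Nothing available explains these steps.

Still open, on these data alone, is whether a pyridinyl ring, with a single ring nitrogen, gives a step of similar size. Also open, as far as these compounds go, is whether an amine or methoxy group on the pyrimidine ring changes the number.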